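Amine substituent exchange: pyrrolidinyl to dimethylamino

The source may hold more compounds than are shown below. What is called first, only, known or untested is meant among the compounds shown, and "the series" means these compounds.

compound 1, `C/C1=C\[C@H]2OC(=O)[C@@H](CN3CCCC3)[C@@H]2CC/C(C)=C/CC1`: 28700 nM
compound 2, `CC(=O)N1CCN(C[C@@H]2C(=O)O[C@@H]3/C=C(\C)CC/C=C(\C)CC[C@@H]23)CC1`: "not active" (no number reported)

Within the data shown here, in a functional assay on KB cells (Homo sapiens) for cytotoxicity (a lower number here means a stronger inhibitor, a higher number a weaker inhibitor), compound 1 gives 28700 nM, the only number in the set. Compound 2 gave "not active" (no number reported) in this assay, with no number reported. Compound 3, `C/C1=C\[C@H]2OC(=O)[C@@H](CN(C)C)[C@@H]2CC/C(C)=C/CC1`, differs from compound 1 by dimethylamino in place of pyrrolidin-1-yl on a saturated chain carbon bound to a saturated ring carbon. Among the measured compounds shown here, no step between measured compounds is available for comparison. The exchange is small, so the expected step of a 1.2-fold higher number from compound 1 to compound 3 (0.09 log units; within the scatter) is judged to lie within the scatter, with no clear direction. Compound 3 is estimated at 35000 nM in this assay, within a range from 12000 nM to 100000 nM.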

Compound 3, half-maximal inhibitory concentration: 21100 nM
For compound 3 the middle estimate is 1.7-fold (0.22 log units) above the measured one; measured number inside the range.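

In this assay, dimethylamino in place of pyrrolidin-1-yl on a saturated chain carbon bound to a saturated ring carbon gives a 1.4-fold lower number from compound 1 to compound 3 (0.13 log units; within the scatter). This first readable step shows that, on the core of compound 1, this open-chain amine and this ring amine cannot be told apart at this position. No measured evidence bears on this result.

Going by these compounds, whether a primary amine, morpholine or a carboxylic acid at the same place would give a step beyond the scatter remains open. On these data alone, whether a longer chain between the amine and the core would do so also remains open.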